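Dichlorophenyl Sulfone Analogue: Expected Human Microsomal Clearance

A few compounds are considered here, and "the series" means these few. Any claim that something is new, unique, unknown or untested is made for them only; others in the source may bear on it.

The pair studied here shares one core and differs only in the aryl group on the sulfonyl sulfur. Compound 1 `O=S(=O)(c1ccc(F)c(Cl)c1)c1cnc2c(F)cccc2c1-c1ccc(Cl)cc1` carries a 3-chloro-4-fluorophenyl there, and in an ADME assay on microsomes from liver (Homo sapiens) for metabolic stability, tested at 2.5 uM (a higher number here means faster removal of the compound, a lower number slower removal), compound 1 gives 0.01 mL/min. Compound 2 `O=S(=O)(c1cccc(F)c1)c1cnc2c(F)cccc2c1-c1ccc(Cl)cc1` carries a 3-fluorophenyl instead, and in this assay compound 2 gives 0.62 mL/min. That single exchange produced a 62-fold higher number from compound 1 to compound 2 (1.79 log units; beyond the scatter), so compound 2 stands as the higher of the two numbers measured, with compound 1 far beneath it.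

Compound 3 `O=S(=O)(c1cc(Cl)cc(Cl)c1)c1cnc2c(F)cccc2c1-c1ccc(Cl)cc1` has not yet been measured. Its structure is compound 2 altered in one place: 3,5-dichlorophenyl in place of 3-fluorophenyl on a sulfonyl sulfur. For the measured compounds named here, the only measured step that bears on this change is the one from compound 1 to compound 2, which was large and ran from a chlorine-bearing aryl group to one without chlorine. Compound 3 reintroduces chlorine, twice, on the same aryl group, so compound 3 is expected to fall back toward compound 1 in this assay, with an estimated step of a 10-fold lower number from compound 2 to compound 3 (1.01 log units; beyond the scatter). Compound 3 is therefore estimated at 0.06 mL/min, within a range from 0.01 mL/min to 0.35 mL/min.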

Compound 3, intrinsic clearance in a liver preparation (reported as CLH), per the amount of preparation that the assay uses: 0.78 mL/min
Compound 3: middle estimate off by 13-fold (1.11 log units), on the low side, and the stated range ends below it.
By their numbers in this assay, from the lowest: compound 1; then compounds 2 and 3 (each within the scatter of the next).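

In this assay the exchange of 3-fluorophenyl for 3,5-dichlorophenyl on the sulfonyl sulfur gives a 1.3-fold higher number from compound 2 to compound 3 (0.10 log units; within the scatter) and so leaves the read-out unresolved from that of the fluorinated analogue, even though the aryl group now carries chlorine in place of fluorine. The exchange of 3-chloro-4-fluorophenyl for 3,5-dichlorophenyl at the same place gives a 78-fold higher number from compound 1 to compound 3 (1.89 log units; beyond the scatter) and so shows that chlorine on this aryl group does not by itself go with a low number, since compound 3 carries two chlorines and still stands well clear of compound 1 at the far end of the series. Of the three aryl groups compared here, only the 3-chloro-4-fluorophenyl stands apart, and nothing measured in this set accounts for that difference.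

The compounds shown leave open whether the low number of compound 1 depends on its chlorine and fluorine occurring together on one ring. They also leave open how this assay would respond to a quite different group on the sulfonyl sulfur, such as a methoxy-bearing phenyl or an amine.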